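Chlorine Added to the Urea Aryl Ring

This account rests on a few compounds, and the source may have more. Where it says the series, first, only, none or still open, it means among the compounds named here.

Three compounds have been measured in a functional assay on HOP-92 cells (Homo sapiens) for inhibition, read by sulforhodamine B assay, with a stated time of 48 h; on this read-out lower numbers stand for stronger inhibition of growth and higher numbers for weaker inhibition of growth:
compound 1 `COc1cc(-c2nn(-c3cccc(NC(=O)Nc4cc(C(F)(F)F)cc(C(F)(F)F)c4)c3)cc2-c2ccncc2)ccc1Cl` with 1150 nM
compound 2 `COc1cc(-c2nn(-c3cccc(NC(=O)Nc4ccc(Cl)c(Cl)c4)c3)cc2-c2ccncc2)ccc1Cl` with 1470 nM
compound 3 `COc1cc(-c2nn(-c3cccc(NC(=O)Nc4cccc(C(F)(F)F)c4)c3)cc2-c2ccncc2)ccc1Cl` with 1770 nM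

Compound 3 has the highest of the three numbers, but the others lie close. The step of a 1.2-fold higher number from compound 2 to compound 3 (0.08 log units; within the scatter) and the step of a 1.5-fold higher number from compound 1 to compound 3 (0.19 log units; within the scatter) are both within the scatter, so these three compounds cannot be ranked on this evidence.

Compound 4 `COc1cc(-c2nn(-c3cccc(NC(=O)Nc4ccc(Cl)c(C(F)(F)F)c4)c3)cc2-c2ccncc2)ccc1Cl` has not yet been measured. It differs from compound 3 by chloro in place of hydrogen on an aromatic carbon. Read one bond further out, the change is 3-(trifluoromethyl)phenyl to 4-chloro-3-(trifluoromethyl)phenyl, the chloro entering on a six-membered aromatic ring of carbon only, ortho to a trifluoromethyl group and para to a large group.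

Among the compounds with values here, two measured steps bear on this. a 1.5-fold higher number from compound 1 to compound 3 (0.19 log units; within the scatter) removes a trifluoromethyl from that same ring, and a 1.2-fold higher number from compound 2 to compound 3 (0.08 log units; within the scatter) exchanges a dichlorophenyl for a trifluoromethylphenyl. Neither moves the number beyond the scatter. A single chloro on this ring is therefore expected to produce no step beyond the scatter. The expected step of a 1.3-fold lower number from compound 3 to compound 4 (0.10 log units; within the scatter) is small. For compound 4 the estimate in this assay is 1400 nM, with a range from 700 nM to 2800 nM.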

Compound 4, concentration for total growth inhibition: 1480 nM
Compound 4: middle estimate off by 1.1-fold (0.02 log units), on the low side; the measured number falls inside the stated range.
By their numbers in this assay, from the lowest: compounds 1, 2, 4 and 3 (each within the scatter of the next).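

In this assay, within the data shown here, a chloro entering ortho to the trifluoromethyl group and para to a large group gives a 1.2-fold lower number from compound 3 to compound 4 (0.08 log units; within the scatter) and thus adds a direct reading at this place on the ring, where the earlier steps had only removed a trifluoromethyl group or exchanged one substituted phenyl for another. The new pair with compound 2 holds the 4-chloro fixed and puts trifluoromethyl in place of the other chloro, giving a 1.0-fold higher number from compound 2 to compound 4 (0.00 log units; within the scatter) and showing that these two groups cannot be told apart here when the 4-chloro is present. No measurement shown gives a reason why either change leaves the number within the scatter.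

On these data alone, the aryl ring of the urea carries only chloro and trifluoromethyl groups in these four compounds, so it remains open whether an amine, a carboxylic acid or a longer alkyl chain at the same place would also leave the number within the scatter or would produce a clear step. As far as these compounds go, it is also open whether any change on this ring can move the number beyond the scatter in this assay at all.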